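Changing the ester group: expected cytotoxicity of compound 4

The source may hold more compounds than are shown below. What is called first, only, known or untested is meant among the compounds shown, and "the series" means these compounds.

Compound 3 `O=C(OCCc1c(-c2ccccc2Cl)c2cc(Cl)ccc2[nH]c1=O)C1CCCC1` was tested in an ADME assay on HepG2 2.2.15 cells (Homo sapiens) for cytotoxicity (on this read-out higher numbers stand for lower toxicity in this test and lower numbers for higher toxicity in this test), where compound 3 gives 46000 nM. Compound 1 `Cn1c(=O)c(CCO)c(-c2ccccc2Cl)c2cc(Cl)ccc21` gives 34000 nM in this assay, and the two values lie within the scatter of each other. Compound 2 `O=c1c(CCO)c(-c2ccccc2Cl)c2cc(Cl)ccc2n1-c1c(F)cccc1F` gives > 2300000 nM in this assay, which is a limit of the assay and not a number. That is the limit of > 2300000 nM in this assay, at which 1 of the 3 values shown sits. Among the measured compounds shown here, the only measured step, an at least 67-fold higher number from compound 1 to compound 2 (1.83 log units; beyond the scatter), concerns the group on the aromatic nitrogen, not the ester, so no measured step bears on the change to compound 4 `O=C(/C=C/c1cccc(C(F)(F)F)c1)OCCc1c(-c2ccccc2Cl)c2cc(Cl)ccc2[nH]c1=O`: 2-(3-(trifluoromethyl)phenyl)ethenyl in place of cyclopentyl on a carbonyl carbon. For the measured compounds named here, with no comparable step to draw on, no change beyond the scatter is expected; compound 4 is estimated at 40000 nM, between 14000 nM and 120000 nM, an expected step of a 1.2-fold lower number from compound 3 to compound 4 (0.06 log units; within the scatter).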

Compound 4, half-maximal cytotoxic concentration: > 1400000 nM
Compound 4 gave a limit, no number (the forecaster's own chance of this, stated with the estimate: 5%); at least 35-fold (1.54 log units) between middle value and limit.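

In this assay, the group on the carbonyl carbon of the ester proves able to shift the read-out strongly: an at least 30-fold higher number from compound 3 to compound 4 (1.48 log units; beyond the scatter). Earlier, only the group on the aromatic nitrogen, which differs between compound 1 and compound 2, had shown a step of this kind. The value of compound 4 is a limit of the assay, not a number: the limit of > 1400000 nM in this assay, at which 1 of the 4 values shown sits.

From the compounds shown here alone, it remains open which part of the entering group carries the step: the double bond, the aromatic ring or the trifluoromethyl. A plain phenyl or a saturated two-carbon chain ending in phenyl on the carbonyl carbon would help separate these parts.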